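From a Fluorophenyl to a Bromophenyl in Compound 3

This account rests on a few compounds, and the source may have more. Where it says the series, first, only, none or still open, it means among the compounds named here.

Compound 1 `O=C(Nc1cccc(OCc2cn(-c3ccccc3F)nn2)c1)Nc1ccc(Cl)c(C(F)(F)F)c1`: 1520 nM
Compound 2 `O=C(Nc1cccc(OCc2cn(-c3cccc(F)c3)nn2)c1)Nc1ccc(Cl)c(C(F)(F)F)c1`: 2120 nM

Both compounds were tested in a functional assay on HepG2 cells (Homo sapiens) for inhibition, read by MTT assay, with a stated time of 72 h; on this read-out higher numbers stand for weaker inhibition and lower numbers for stronger inhibition. Among the compounds with values here, on this read-out compound 2 gives the higher of the two numbers, with compound 1 its only neighbour; the one measured step, a 1.4-fold higher number from compound 1 to compound 2 (0.14 log units; within the scatter), lies within the scatter, so the two values cannot be ordered.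

Compound 3 `O=C(Nc1cccc(OCc2cn(-c3ccccc3Br)nn2)c1)Nc1ccc(Cl)c(C(F)(F)F)c1` differs from compound 2 in one place: 2-bromophenyl in place of 3-fluorophenyl on an aromatic nitrogen. Two things change at once. The group returns to the position it holds in compound 1, and the fluorine becomes a bromine. Within the data shown here, the only measured step that bears on this is a 1.4-fold higher number from compound 1 to compound 2 (0.14 log units; within the scatter), which moved the fluorine between those two positions and stayed within the scatter. Among the measured compounds shown here, no measured step tells what exchanging fluorine for bromine does here. A step in this assay of no clear direction beyond the scatter is therefore expected, a 1.2-fold lower number from compound 2 to compound 3 (0.10 log units; within the scatter), and compound 3 is estimated at 1700 nM, with a range from 800 nM to 3600 nM.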

Compound 3, half-maximal inhibitory concentration: 2810 nM
For compound 3 the middle estimate is 1.7-fold (0.22 log units) below the measured one; measured number inside the range.
By their numbers in this assay, from the lowest: compounds 1, 2 and 3 (each within the scatter of the next).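

In this assay, within the data shown here, the exchange of bromo for fluoro on an aromatic carbon gives a 1.8-fold higher number from compound 1 to compound 3 (0.27 log units; within the scatter) and so stays within the scatter, the first reading of this exchange at this position. The combined change from 3-fluorophenyl to 2-bromophenyl gives a 1.3-fold higher number from compound 2 to compound 3 (0.12 log units; within the scatter) and also stays within the scatter, so on this read-out neither the kind of halogen nor its place on the phenyl ring separates these three compounds. Nothing measured on these compounds bears on this result.

The compounds shown leave open whether a group other than a halogen on this phenyl ring, such as an amine, a methoxy group or a carboxylic acid, would give a step beyond the scatter. They also leave open what a plain methyl or a longer alkyl chain would do in place of the whole phenyl ring on the aromatic nitrogen.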